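From Aryl Amide to Hydroxamic Acid: Expecting Compound 4

A few compounds are considered here, and "the series" means these few. Any claim that something is new, unique, unknown or untested is made for them only; others in the source may bear on it.

Compound 1, whose structure is `COc1ccc(NC(=O)[C@@H]2CC=C(CCC=C(C)C)C[C@H]2c2ccccc2)cc1`, was tested in an assay on isolated protein for inhibition of Apoptosis regulator Bcl-2 (Homo sapiens), read by fluorescence polarization, with stated times of 5 min and 10 min; a higher number here means a weaker inhibitor, a lower number a stronger inhibitor. In this assay compound 1 gives > 23000 nM, which is not a number but the limit of the assay. Two relatives stand in the same place. Compound 2, with structure `CC(C)=CCCC1=CC[C@H](C(=O)Nc2ccc(O)cc2)[C@@H](c2ccccc2)C1`, gives > 23000 nM in this assay, again only a limit. Compound 3, with structure `CON(C)C(=O)[C@@H]1CC2=C(CCCC2(C)C)C[C@H]1c1ccccc1`, gives > 23000 nM in this assay, also a limit. For the measured compounds named here, all three measured compounds therefore sit at the limit of > 23000 nM in this assay, at which 3 of the 3 values shown sit, and no step between two measured numbers exists to show how any change in structure moves the read-out.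

Compound 4, whose structure is `CC(C)=CCCC1=CC[C@@H](C(=O)NO)[C@H](c2ccccc2)C1`, has not yet been measured. It differs from compound 1 in one place: hydroxy in place of 4-methoxyphenyl on an amide-type nitrogen. The aryl amide of compound 1 thereby becomes a hydroxamic acid, while the shared core stays the same. Going by the values given here, because every measured relative sits at the limit of > 23000 nM in this assay, at which 3 of the 3 values shown sit, there is no measured step on which to build a direction, and the change is expected to bring nothing beyond the scatter. The step from compound 1 to compound 4 in this assay is expected to be a step that the limit leaves unreadable from compound 1 to compound 4. For compound 4 the estimate in this assay is 30000 nM, within a range from 8000 nM to 120000 nM, most likely reported again only as a limit.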

Compound 4, inhibition constant: 700 nM
Compound 4: middle estimate off by 43-fold (1.63 log units), on the high side, and the stated range ends above it.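

Compound 1 gives > 23000 nM in this assay, and this is a limit of the assay, not a number. Putting hydroxy in place of 4-methoxyphenyl on the amide-type nitrogen, with the shared core kept, gives an at least 32-fold lower number from compound 1 to compound 4 (1.51 log units; beyond the scatter), so this position can carry a large change in the read-out, and the small hydroxy is enough to bring it about while the larger aromatic group is not needed for binding to be detected. The earlier compounds could not show this, as none of them gave a readable value and so none offered a step to compare, and compound 4 is the only one that leaves the shared ceiling: the limit of > 23000 nM in this assay, at which 3 of the 4 values shown sit.

Going by these compounds, the true size of the step stays unknown, as only one end of it is a number, and a single change cannot tell whether the hydroxy itself, the small size of the new group or the whole hydroxamic acid matters most. A methoxy group or a plain hydrogen on the same nitrogen, or a carboxylic acid in place of the whole hydroxamic acid, would help to separate these readings on the same core.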